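Capping an Amine Where Neither Measured Compound Shows Activity

The source may report more compounds than this note shows. Statements on the series, on what has been measured and on what is new or still open speak of the compounds shown alone.

Compound 1, `CCCn1c(NC(=O)c2nccc3ccccc23)nc2cc(C(N)=O)cc(OC)c21`: > 100000 nM in an assay for activation of interferon regulatory factor 3 (Homo sapiens), read by a luciferase reporter, with a stated time of 20 h; a lower number here means that less compound is needed, a higher number that more compound is needed for the effect
Compound 2, `CCn1nc(C)cc1C(=O)Nc1nc2cc(C(N)=O)cc(OC)c2n1CCCN`: > 100000 nM

In this assay compound 1 gives > 100000 nM, which is a limit of the assay. Compound 2 gives > 100000 nM, also a limit. For the measured compounds named here, compound 2 therefore stands at the limit of > 100000 nM in this assay, at which 2 of the 2 values shown sit, and no measured step between compounds can be sized. Compound 3, `CCn1nc(C)cc1C(=O)Nc1nc2cc(C(N)=O)cc(OC)c2n1CCCNC(=O)OC(C)(C)C`, differs from compound 2 by tert-butoxycarbonyl in place of hydrogen on an amine nitrogen. With both measured values sitting at the limit, no movement beyond the usual scatter is expected in this assay. Compound 3 is expected to give 100000 nM, within 30000 nM to 300000 nM, most likely reported again as a limit. The expected step is a number no higher from compound 2 to compound 3 (the limit leaves the size open).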

Compound 3, half-maximal effective concentration: > 100000 nM
Compound 3 gave a limit, no number (the forecaster's own chance of this, stated with the estimate: 85%); the middle value lies on the limit itself.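

For the compounds shown here, compound 2 and compound 3 both give only a limit in this assay, so no step between them can be read. The compounds shown leave open which structure, if any, gives a measurable number: the limit of > 100000 nM in this assay, at which 3 of the 3 values shown sit.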